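Hydroxy on the methoxyphenyl ring across two dithiole cores

The source may hold more compounds than are shown below. What is called first, only, known or untested is meant among the compounds shown, and "the series" means these compounds.

The series rests on four compounds that share a trimethoxyphenyl-substituted dithiole bearing a second aryl ring. Compound 1 `COc1ccc(-c2ssc(=S)c2-c2cc(OC)c(OC)c(OC)c2)cc1` carries a 4-methoxyphenyl group and a thioxo group on its core; in a functional assay on HT-1080 cells (Homo sapiens) for antiproliferative activity, read by MTT assay, with a stated time of 72 h (a lower number here means a stronger inhibitor, a higher number a weaker inhibitor), compound 1 gives 18600 nM. Compound 2 `COc1ccc(-c2ssc(=S)c2-c2cc(OC)c(OC)c(OC)c2)cc1O` differs from it only by hydroxy in place of hydrogen on an aromatic carbon, and in this assay compound 2 gives 231 nM. This single change made an 81-fold lower number from compound 1 to compound 2 (1.91 log units; beyond the scatter).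

Compound 3 `COc1ccc(-c2ssc(=O)c2-c2cc(OC)c(OC)c(OC)c2)cc1` keeps the 4-methoxyphenyl group but its core carries an oxo group in place of the thioxo group; how the two cores differ is not broken down here. In this assay compound 3 gives 464 nM, a value that sits within the scatter of compound 2 and well away from compound 1.

Compound 4 `COc1ccc(-c2ssc(=O)c2-c2cc(OC)c(OC)c(OC)c2)cc1O` is the oxo-core counterpart of compound 2: it differs from compound 3 by hydroxy in place of hydrogen on an aromatic carbon, the same change that separates compound 1 from compound 2. Because the earlier step was an 81-fold lower number from compound 1 to compound 2 (1.91 log units; beyond the scatter), a marked drop in number is expected for compound 4 as well. The step from compound 3 to compound 4 in this assay is estimated at a 19-fold lower number from compound 3 to compound 4 (1.27 log units; beyond the scatter), a somewhat smaller step than the earlier one, because compound 3 already stands at 464 nM, far lower than where compound 1 began. For compound 4 in this assay the expected value is 25 nM, with a plausible range from 5 nM to 120 nM.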

Compound 4, half-maximal inhibitory concentration: 1910 nM
For compound 4 the middle estimate is 76-fold (1.88 log units) below the measured one; the measured number lies above the stated range.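

Carried from one core to the other, the hydroxy change does not keep its sign in this assay. On the oxo core it gives a 4.1-fold higher number from compound 3 to compound 4 (0.61 log units; beyond the scatter), whereas on the thioxo core it gave an 81-fold lower number from compound 1 to compound 2 (1.91 log units; beyond the scatter), and the two steps differ in direction and in size: the same change on two cores in this assay, an 81-fold lower number (1.91 log units; beyond the scatter) from compound 1 to compound 2 and a 4.1-fold higher number (0.61 log units; beyond the scatter) from compound 3 to compound 4, 330-fold (2.52 log units) apart, beyond the scatter of two such steps

So, within these four compounds, the step from 4-methoxyphenyl to 3-hydroxy-4-methoxyphenyl measured on one core cannot be transferred to the other, and neither its size nor its direction can be assumed. Within the data shown here, the result rests on only two matched pairs, however, and it does not show why the cores diverge, nor whether any other change on this ring would diverge in the same way.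

The compounds shown leave open whether an amine or a fluorine in the place of the hydroxy would follow the thioxo pair, the oxo pair or neither. They also leave open whether the same split between the cores would persist with an ethoxy group in place of the methoxy group on that ring.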